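The source may report more compounds than this note shows. Statements on the series, on what has been measured and on what is new or still open speak of the compounds shown alone.

Among the measured compounds shown here, compound 2 `COc1cc(NC(=O)c2cncc(N3CC4CC(C3)N4)c2)cc(OC)c1` stands highest of the three numbers so far measured in an assay on cells for displacement of a labelled ligand from Neuronal acetylcholine receptor; alpha3/beta4 (Homo sapiens) (a higher number here means a weaker inhibitor, a lower number a stronger inhibitor), where compound 2 gives 2000 nM. Compound 1 `O=C(Nc1cccc(F)c1)c1cncc(N2CC3CC(C2)N3)c1` gives 28 nM, and compound 3 `O=C(Nc1ccc(F)cc1)c1cncc(N2CC3CC(C2)N3)c1` gives 81 nM. For the measured compounds named here, the one measured step between compounds that differ in a single place is a 2.9-fold higher number from compound 1 to compound 3 (0.46 log units; beyond the scatter), a modest change that does not touch a methoxy group and so bears only loosely on what follows. Going by the values given here, no measured pair isolates the change from compound 2 to compound 4 `COc1cccc(NC(=O)c2cncc(N3CC4CC(C3)N4)c2)c1`, namely (hydrogen in place of methoxy on an aromatic carbon). What the numbers do show is that both fluorophenyl amides sit far lower than compound 2, although they differ from it in more than one place. For compound 4, which keeps one methoxy group, a marked drop in this assay is expected, a 6.7-fold lower number from compound 2 to compound 4 (0.82 log units; beyond the scatter). Compound 4 is accordingly estimated at 300 nM, with a likely range from 80 nM to 1200 nM.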

Compound 4, inhibition constant: 265 nM
The estimate for compound 4 lay 1.1-fold (0.05 log units) above the measured number; low and high end bracket the measured number.
By their numbers in this assay, from the lowest: compound 1; then compound 3; then compound 4; then compound 2.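

Taking away one of the two methoxy groups recovers much of the lost ground in this assay, with a 7.5-fold lower number from compound 2 to compound 4 (0.88 log units; beyond the scatter), so the second methoxy on this aromatic carbon clearly weighs against binding in this series. The remaining methoxy still does not match fluorine, since the change gives a 9.5-fold higher number from compound 1 to compound 4 (0.98 log units; beyond the scatter) and the swap of aryl groups gives a 3.3-fold higher number from compound 3 to compound 4 (0.51 log units; beyond the scatter), which places compound 4 between compound 2 and both fluorophenyl amides. Nothing measured here explains the size of these steps.

The compounds shown leave open whether a phenyl ring carrying only hydrogen would sit lower still than compound 4. They also leave open how a hydroxyl, an amine or a chlorine on this ring would compare with the methoxy and fluoro groups.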